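Nitro for Hydroxy on the Enaminone Aryl Ring

The source may hold more compounds than are shown below. What is called first, only, known or untested is meant among the compounds shown, and "the series" means these compounds.

Measured so far:
compound 1 `COc1cc(OC)c2sc(-c3ccc(N/C=C\C(=O)c4ccc(OC)c(O)c4)c(C)c3)nc2c1` gives 3100 nM
compound 2 `COc1cc(OC)c2sc(-c3ccc(N/C=C\C(=O)c4ccc(OC)c([N+](=O)[O-])c4)c(C)c3)nc2c1` gives 10800 nM
compound 3 `COc1ccc(C(=O)/C=C\Nc2ccc(-c3nc4cc(OC)c(OC)c(OC)c4s3)cc2)cc1O` gives 18100 nM

All numbers come from a functional assay on MDA-MB-231 cells (Homo sapiens) for antiproliferative activity, read by sulforhodamine B assay, with a stated time of 48 h; a lower number here means a stronger inhibitor, a higher number a weaker inhibitor. Compound 1 and compound 2 share one core; compound 3 carries another, and the difference between the two cores is not broken down here. Compound 3 and compound 2 lie within the scatter of each other, while compound 1 stands well apart from compound 3. For the measured compounds named here, the one counted change, (nitro in place of hydroxy on an aromatic carbon), gave a 3.5-fold higher number from compound 1 to compound 2 (0.54 log units; beyond the scatter). Compound 4 `COc1ccc(C(=O)/C=C\Nc2ccc(-c3nc4cc(OC)c(OC)c(OC)c4s3)cc2)cc1[N+](=O)[O-]` repeats the same change on the core of compound 3, (nitro in place of hydroxy on an aromatic carbon), at an identical place. Going by the values given here, from compound 3 the step is expected to be a 2.8-fold higher number from compound 3 to compound 4 (0.44 log units; beyond the scatter), resting on the single measured instance of this change, a 3.5-fold higher number from compound 1 to compound 2 (0.54 log units; beyond the scatter). Compound 4 is estimated at 50000 nM, plausibly between 15000 nM and 160000 nM.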

Compound 4, half-maximal inhibitory concentration: 17100 nM
Compound 4: the middle estimate sits 2.9-fold (0.47 log units) above what was measured; the range from low to high includes it.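

In this assay, nitro in place of hydroxy on the core of compound 3 gave a 1.1-fold lower number from compound 3 to compound 4 (0.02 log units; within the scatter), so no effect of the change can be read on this core. The change therefore did not carry over in size between the two cores: the same change on two cores in this assay, a 3.5-fold higher number (0.54 log units; beyond the scatter) from compound 1 to compound 2 and a 1.1-fold lower number (0.02 log units; within the scatter) from compound 3 to compound 4, 3.7-fold (0.57 log units) apart, beyond the scatter of two such steps. These two pairs show that a step measured on one core cannot be transferred directly to the other in this series, but they do not show which difference between the cores matters or how the change would read on a further core.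

Still open, going by these compounds, is whether an amine or a carboxylic acid at the same place on the aromatic ring would read alike on both cores. Also open, on these data alone, is whether the gap between the two cores extends beyond the hydroxy and nitro pair.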